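Stability notes: tert-butyl for phenyl on the aryl amine

This account rests on a few compounds, and the source may have more. Where it says the series, first, only, none or still open, it means among the compounds named here.

Measured so far in an ADME assay on microsomes from liver (Homo sapiens) for metabolic stability, read by mass spectrometry, with a stated time of 10 min, tested at 0.5 uM; on this read-out lower numbers stand for a less stable compound and higher numbers for a more stable compound:
compound 1 `CNc1cc(Nc2cccc(-c3ccccc3)c2)nn2c(C(N)=O)cnc12` gives 51%
compound 2 `CNc1cc(Nc2cc(C)cc(C)c2)nn2c(C(=O)NCC(C)(C)CO)cnc12` gives 20%
compound 3 `CNc1cc(Nc2c(F)c(F)cc(F)c2F)nn2c(C(=O)NC[C@](C)(O)CO)cnc12` gives 100%

Three compounds share the core, and the numbers spread widely. Compound 1 stands second highest of the three: compound 2 sits a long way lower, beyond the scatter, and compound 3 sits higher by an even larger gap, also beyond the scatter. The three differ in several places at once, so no single change can be read from any pair.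

Compound 4 `CNc1cc(Nc2cccc(C(C)(C)C)c2)nn2c(C(N)=O)cnc12` has not yet been run in this assay. Against compound 1 the change is tert-butyl in place of phenyl on an aromatic carbon. Within the data shown here, no measured pair shows this change, so the expectation rests only on the value of compound 1 and the general spread of the set. The step of a number 6 percentage points lower from compound 1 to compound 4 (within the scatter) is expected to be small, at most a modest decrease, and may well fall within the scatter. Compound 4 is therefore estimated at 45%, with a range from 20% to 75%.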

Compound 4, percent of the compound remaining: 41%
The estimate for compound 4 lay 4 percentage points above the measured number, within the range that was stated.
By their numbers in this assay, from the lowest: compound 2; then compounds 4 and 1 (each within the scatter of the next); then compound 3.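

In this assay the change of phenyl to tert-butyl on an aromatic carbon, meta to a large group, gives a number 10 percentage points lower from compound 1 to compound 4 (within the scatter). Among these compounds, this is the first pair that differs in one place, so the effect of a single change can now be read directly. At this position, a six-membered aromatic ring of carbon only can give way to tert-butyl, which has no ring and fewer heavy atoms, without a step beyond the scatter, and no measurement here explains this result.

As far as these compounds go, it remains open whether an amine, a carboxylic acid or a longer chain at the same place would also stay within the scatter of compound 1. Also open, from the compounds shown here alone, is whether tert-butyl for phenyl would read the same with the amide side chains of compound 2 and compound 3.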